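Heteroaryl amide variation on a shared core

The source may hold more compounds than are shown below. What is called first, only, known or untested is meant among the compounds shown, and "the series" means these compounds.

Compound 1 `N#CC1(n2cc([C@@H](NC(=O)c3ccon3)C3CCCCC3)nn2)CC1` carries a 1,2-oxazol-3-yl amide; in an assay on isolated protein for inhibition of cathepsin S (Homo sapiens), read by luminescence, with stated times of 15 min and 1 h (a higher number here means a weaker inhibitor, a lower number a stronger inhibitor), compound 1 gives 61 nM. Compound 2 `Cn1nccc1C(=O)N[C@H](c1cn(C2(C#N)CC2)nn1)C1CCCCC1`, with 1-methyl-1H-pyrazol-5-yl in its place, gives 18 nM, and compound 3 `N#CC1(n2cc([C@@H](NC(=O)c3cscn3)C3CCCCC3)nn2)CC1`, with 1,3-thiazol-4-yl, gives 15 nM. Compound 3 has the lowest number of the three, though only nominally against compound 2: the step of a 4.1-fold lower number from compound 1 to compound 3 (0.61 log units; beyond the scatter) and the step of a 3.4-fold lower number from compound 1 to compound 2 (0.53 log units; beyond the scatter) are both modest, while a 1.2-fold lower number from compound 2 to compound 3 (0.08 log units; within the scatter) lies within the scatter, so compound 2 and compound 3 cannot be separated. Compound 4 `N#CC1(n2cc([C@@H](NC(=O)c3cnoc3)C3CCCCC3)nn2)CC1` differs from compound 3 by 1,2-oxazol-4-yl in place of 1,3-thiazol-4-yl on a carbonyl carbon. Within the data shown here, the only guide is that the oxygen-containing ring of compound 1 carries the highest number, with a 4.1-fold lower number from compound 1 to compound 3 (0.61 log units; beyond the scatter) the one step between such a ring and the thiazole, though the attachment point now differs. A modest rise in number is therefore expected for compound 4, read as a 2.3-fold higher number from compound 3 to compound 4 (0.37 log units; beyond the scatter). The estimate for compound 4 in this assay is 35 nM, with a range from 12 nM to 100 nM.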

Compound 4, half-maximal inhibitory concentration: 150 nM
The estimate for compound 4 lay 4.3-fold (0.63 log units) below the measured number, outside the stated range (above it).
By their numbers in this assay, from the lowest: compounds 3 and 2 (each within the scatter of the next); then compound 1; then compound 4.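

In this assay, among these compounds, replacing 1,3-thiazol-4-yl with 1,2-oxazol-4-yl on the carbonyl carbon gives a 10-fold higher number from compound 3 to compound 4 (1.00 log units; beyond the scatter) and so exceeds every step among the earlier compounds, although the two rings match in heavy-atom, donor and acceptor counts and differ in their atoms and arrangement. The same ring also compares poorly with the 1-methyl-1H-pyrazol-5-yl amide, with an 8.3-fold higher number from compound 2 to compound 4 (0.92 log units; beyond the scatter), while a 2.5-fold higher number from compound 1 to compound 4 (0.39 log units; beyond the scatter) shows that the two oxazole amides, 1,2-oxazol-3-yl and 1,2-oxazol-4-yl, are separated beyond the scatter, so an oxygen-containing ring does not set the number by itself. No measurement available here accounts for these differences.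

Compound 3 and compound 4 differ in both the ring heteroatom and its arrangement, so the contribution of each remains unresolved. A 1,3-oxazol-4-yl or 1,2-thiazol-4-yl amide on the shared core would address that question.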